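Swapping the benzyl substituent: methyl to fluorine

The source may hold more compounds than are shown below. What is called first, only, known or untested is meant among the compounds shown, and "the series" means these compounds.

Within the data shown here, compound 2 `Cc1ccc(COc2ccc(C(=O)NC(=S)Nc3ccc(C)c(-c4nc5ccccc5[nH]4)c3)cc2)cc1` carries a 4-methylbenzyl group on the aromatic oxygen of a shared core; in a functional assay on MNK45 cells (Homo sapiens) for inhibition, read by MTT assay, with a stated time of 48 h (a lower number here means a stronger inhibitor, a higher number a weaker inhibitor), compound 2 gives 11300 nM, the highest of the two numbers known so far. Its closest neighbour is compound 1 `Cc1ccc(NC(=S)NC(=O)c2ccc(OCc3cccc(C(F)(F)F)c3)cc2)cc1-c1nc2ccccc2[nH]1`, which in this assay gives 6050 nM; the step of a 1.9-fold higher number from compound 1 to compound 2 (0.27 log units; within the scatter) shows that replacing one substituted benzyl group with another changed little here. Compound 3 `Cc1ccc(NC(=S)NC(=O)c2ccc(OCc3cccc(F)c3)cc2)cc1-c1nc2ccccc2[nH]1` continues in the same spot: 3-fluorophenyl in place of 4-methylphenyl on a saturated chain carbon bound to an oxygen on an aromatic ring. Among the measured compounds shown here, only the step from compound 1 to compound 2 bears on this, and it stayed within the scatter, so for compound 3 no movement beyond the scatter is expected, with at most a slight drift back toward the number of compound 1 a 1.5-fold lower number from compound 2 to compound 3 (0.18 log units; within the scatter). The estimated value for compound 3 in this assay is 7500 nM, with a likely range from 3000 nM to 18000 nM.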

Compound 3, half-maximal inhibitory concentration: 86800 nM
Estimate against measurement, compound 3: 12-fold (1.06 log units) below; the whole stated range lies below it.
By their numbers in this assay, from the lowest: compounds 1 and 2 (each within the scatter of the next); then compound 3.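

The benzyl group on this oxygen is less forgiving than the first pair suggested: in this assay, 3-fluorophenyl in place of 4-methylphenyl gives a 7.7-fold higher number from compound 2 to compound 3 (0.89 log units; beyond the scatter) and moves the number beyond the scatter. The comparison with compound 1 is sharper still, since fluoro in place of trifluoromethyl on an aromatic carbon gives a 14-fold higher number from compound 1 to compound 3 (1.16 log units; beyond the scatter) and so marks this ring substituent as one that can change the result greatly, even though the step between compound 1 and compound 2 stayed within the scatter. Nothing available explains why the fluoro compound stands so far from the other two.

Going by these compounds, whether 3-chlorophenyl or 3-methoxyphenyl on that same carbon would read like compound 1 or like compound 3 remains open. So does the number for a plain phenyl ring with no substituent at all.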